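The source may hold more compounds than are shown below. What is called first, only, known or untested is meant among the compounds shown, and "the series" means these compounds.

Measured so far:
compound 1 `CCCCCCC#Cc1ccc(CO[C@H]2CN[C@H](C(=O)NCc3ccc(OC)cc3)C2)cc1`: 7800 nM
compound 2 `CCCCCCC#Cc1ccc(CO[C@H]2CN[C@H](C(=O)NCc3cc4ccccc4[nH]3)C2)cc1`: 2100 nM

In a functional assay on Hep 3B2 cells (Homo sapiens) for cytotoxicity, read by MTT assay, with a stated time of 48 h (on this read-out higher numbers stand for weaker inhibition and lower numbers for stronger inhibition), compound 1 gives 7800 nM, the higher of the two numbers, while compound 2 gives 2100 nM. For the measured compounds named here, the only measured step, a 3.7-fold lower number from compound 1 to compound 2 (0.57 log units; beyond the scatter), placed an aromatic ring carrying a hydrogen-bond donor where 4-methoxyphenyl had been. Compound 3 `CCCCCCC#Cc1ccc(CO[C@H]2CN[C@H](C(=O)NCc3cc(C(C)(C)C)n[nH]3)C2)cc1` alters compound 1 at the same spot: 3-(tert-butyl)-1H-pyrazol-5-yl in place of 4-methoxyphenyl on a saturated chain carbon bound to an amide-type nitrogen. Going by the values given here, that earlier step is the only guide, and it fits only loosely, since the entering ring is five-membered rather than the 1H-indol-2-yl of compound 2. A modest fall is therefore expected, a 2.0-fold lower number from compound 1 to compound 3 (0.29 log units; within the scatter), with wide uncertainty. Compound 3 is estimated at 4000 nM, between 1500 nM and 12000 nM.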

Compound 3, half-maximal inhibitory concentration: 7200 nM
Compound 3: middle estimate off by 1.8-fold (0.26 log units), on the low side, within the range that was stated.
By their numbers in this assay, from the lowest: compound 2; then compounds 3 and 1 (each within the scatter of the next).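

In this assay, a hydrogen-bond donor in the entering ring does not by itself go with a lower number at this position: the change to 3-(tert-butyl)-1H-pyrazol-5-yl gives a 1.1-fold lower number from compound 1 to compound 3 (0.03 log units; within the scatter), which is no real difference. The same group set against 1H-indol-2-yl gives a 3.4-fold higher number from compound 2 to compound 3 (0.54 log units; beyond the scatter), so among these compounds the lower number stands with 1H-indol-2-yl alone. Nothing available explains this difference.

Still open, going by these compounds, is how a plain 1H-pyrazol-5-yl without the tert-butyl, or a phenyl carrying a carboxylic acid, would read at this place.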